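One amide swap: from 2-chlorophenyl to 4-methoxyphenyl

The source may hold more compounds than are shown below. What is called first, only, known or untested is meant among the compounds shown, and "the series" means these compounds.

Measured in a functional assay on A549 cells (Homo sapiens) for inhibition, read by MTT assay, with a stated time of 48 h; a higher number here means a weaker inhibitor, a lower number a stronger inhibitor:
- Compound 1 `COc1ccc(CNC(=O)/C=C/c2coc3cc(O)ccc3c2=O)cc1`: > 100000 nM
- Compound 2 `COc1ccc2c(=O)c(/C=C/C(=O)Nc3ccccc3Cl)coc2c1`: 29900 nM

The result for compound 1 is a limit of the assay and not a number. Within the data shown here, that leaves compound 2, at 29900 nM, with the only actual number in this assay, so it cannot yet be ranked against a second measured value.

Compound 3 `COc1ccc(NC(=O)/C=C/c2coc3cc(OC)ccc3c2=O)cc1` has not been measured. It carries 4-methoxyphenyl in place of 2-chlorophenyl on an amide-type nitrogen. Among the measured compounds shown here, no measured pair of compounds shows what such a swap does, so the expectation rests on compound 2 and its 29900 nM alone. A small move toward weaker inhibition is expected, close to the usual scatter, and the estimated step is a 1.5-fold higher number from compound 2 to compound 3 (0.18 log units; within the scatter). For compound 3 the estimated value is 45000 nM, with an expected range of 12000 nM to 100000 nM.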

Compound 3, half-maximal inhibitory concentration: 23000 nM
Compound 3: middle estimate off by 2.0-fold (0.29 log units), on the high side, within the range that was stated.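

Among these compounds, this is the first step that can be read at this position: with 4-methoxyphenyl in place of 2-chlorophenyl on the amide-type nitrogen, this assay gives a 1.3-fold lower number from compound 2 to compound 3 (0.11 log units; within the scatter) and the step stays inside the usual scatter. The two groups therefore cannot be told apart in this assay, even though they differ in their substituent and in where it sits on the ring. So far, this position tolerates this particular exchange between two substituted phenyl rings without a readable change in the number.

Still open, from the compounds shown here alone, is whether a group of another kind on that nitrogen, such as a phenyl ring carrying a carboxylic acid or a longer chain ending in an amine, would move the value beyond the scatter. Such a compound might also give only a limit instead of a number, as has already happened once in this assay: the limit of > 100000 nM in this assay, at which 1 of the 3 values shown sits.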